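A few compounds are considered here, and "the series" means these few. Any claim that something is new, unique, unknown or untested is made for them only; others in the source may bear on it.

Measured so far:
- compound 1 `CNC(=O)c1cc(C(=O)N[C@H]2[C@@H]3COC[C@@H]32)cc2c1OC[C@H]2c1cccnc1`: 1.4
- compound 2 `CNC(=O)c1cc(C(=O)NC)c2c(c1)[C@H](c1ccccc1)CO2`: 3.2
- compound 3 `CNC(=O)c1cc(C(=O)N[C@H]2[C@@H]3COC[C@@H]32)cc2c1O[C@H](CF)[C@H]2c1ccccc1`: 3.6

Of the compounds shown here, three sharing a core have been measured in a physicochemical assay for lipophilicity, at pH 7.4; a higher number here means a more lipophilic compound, a lower number a more polar compound. Compound 1 stands lowest of the three: compound 2 gives 3.2, a number well beyond the scatter above it, and compound 3 gives 3.6, further above it still. Both gaps are beyond the scatter, so compound 1 is clearly the most polar of the three as measured.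

Compound 4 `CNC(=O)c1cc(C(=O)N[C@H]2[C@@H]3COC[C@@H]32)cc2c1OC[C@H]2c1ccccc1C` has not yet been measured in this assay. It differs from compound 1 in one place: 2-methylphenyl in place of pyridin-3-yl on a saturated ring carbon. The change is a 2-methylphenyl in place of a pyridin-3-yl on a saturated ring carbon of the five-membered non-aromatic ring.

Among the compounds with values here, no step between two measured compounds isolates this change, but compound 2 and compound 3, which both carry a carbon-only aromatic ring at that position, sit well above compound 1. On that basis a sizable upward step is expected, well beyond the scatter. The estimated step of a number 1.80 log units higher from compound 1 to compound 4 (beyond the scatter) reflects this, and compound 4 is expected to give about 3.2 in this assay, in the range of 2.6 to 3.8.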

Compound 4, distribution coefficient: 4
Estimate against measurement, compound 4: 0.80 log units below; measured number outside the range, above it.
By their numbers in this assay, from the lowest: compound 1; then compound 2; then compound 3; then compound 4.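

Within the data shown here, compound 4 gives the first step in this set that isolates a single change, here on a saturated ring carbon of the five-membered non-aromatic ring: in this assay, replacing pyridin-3-yl with 2-methylphenyl gives a number 2.60 log units higher from compound 1 to compound 4 (beyond the scatter), a large step that shows the number read in this assay depends strongly on the group at this place when the rest of compound 1 stays fixed. The change removes the ring nitrogen, with the one hydrogen-bond acceptor counted for pyridin-3-yl, and also brings in the methyl group of 2-methylphenyl, so this one step covers both differences and cannot divide its size between them. No measurement shown explains why the step is this large.

As far as these compounds go, the share of the step that belongs to the methyl group remains open, since the core of compound 1 appears here with neither an unsubstituted phenyl nor a methylpyridinyl group at this place. Also open, from the compounds shown here alone, is how the number would respond to a ring carrying a methoxy group, an aminomethyl group or a carboxylic acid on this same core.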